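This account rests on a few compounds, and the source may have more. Where it says the series, first, only, none or still open, it means among the compounds named here.

Compound 1 `O=C1OC(c2ccc([N+](=O)[O-])cc2)=N/C1=C\c1ccncc1` gives 2% in an assay on isolated protein for inhibition of Death-associated protein kinase 3 (Homo sapiens), tested at 10 uM; a lower number here means a weaker effect, a higher number a stronger effect of the compound at the concentration tested.
Compound 2 `O=C1OC(c2cccc(Br)c2)=N/C1=C\c1ccncc1` gives 0%.
Compound 3 `O=C1OC(c2ccc(Cl)c([N+](=O)[O-])c2)=N/C1=C\c1cccnc1` gives 100%.

Among these three numbers compound 2 gives the lowest one. Compound 1 stands within the usual scatter of compound 2, so the two cannot be told apart. Compound 3 stands far beyond the scatter, well above both. Compound 4 `O=C1OC(c2ccccc2)=N/C1=C\c1ccncc1` has not been measured yet; it differs from compound 2 in one place: hydrogen in place of bromo on an aromatic carbon. Among the measured compounds shown here, no pair of measured compounds shows this change, so the size of its effect is not known from the data. The step of a number 3 percentage points higher from compound 2 to compound 4 (within the scatter) is expected to stay within the scatter, in no clear direction, because compound 2 gives 0% in this assay. Compound 4 is estimated at 3%, within -5% to 15%.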

Compound 4, a percentage reported as inhibition, at one concentration (the size of the read-out at that concentration, not a potency): 1%
Beside the measured number, compound 4's estimate is 2 percentage points above it; the range from low to high includes it.
By their numbers in this assay, from the lowest: compounds 2, 4 and 1 (each within the scatter of the next); then compound 3.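

In this assay, hydrogen in place of bromo on an aromatic carbon gives a number 1 percentage points higher from compound 2 to compound 4 (within the scatter), and hydrogen in place of nitro gives a number 1 percentage points lower from compound 1 to compound 4 (within the scatter). Neither bromo nor nitro can therefore be told apart from hydrogen in these compounds, and all three sit so close to zero that a further loss could hardly show. Nothing available explains this result.

On these data alone, whether an amine or a carboxylic acid on that aromatic carbon would raise the read-out stays open. No single-place step links compound 3 to the others, so what lies behind the 100% of compound 3 cannot be read.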